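The source may report more compounds than this note shows. Statements on the series, on what has been measured and on what is new or still open speak of the compounds shown alone.

Series notes. In an assay on cells for inhibition of protein deacetylase HDAC6 (Homo sapiens), with a stated time of 3 h (a higher number here means a weaker inhibitor, a lower number a stronger inhibitor), compound 3 `C#Cc1cccc(Nc2ncnc3cc(NC(=O)CCCCCCC(=O)NO)sc23)c1` gives 21.3 nM, the lowest number of the three measured. Compound 2 `CCc1cccc(Nc2ncnc3cc(NC(=O)CCCCCCC(=O)NO)sc23)c1` gives 58.5 nM and compound 1 `Cc1ccccc1Nc1ncnc2cc(NC(=O)CCCCCCC(=O)NO)sc12` gives 87.6 nM. The steps toward compound 3 read a 2.7-fold lower number from compound 2 to compound 3 (0.44 log units; beyond the scatter) and a 4.1-fold lower number from compound 1 to compound 3 (0.61 log units; beyond the scatter); the remaining pair shows a 1.5-fold lower number from compound 1 to compound 2 (0.18 log units; within the scatter). Compound 4 `N#Cc1cccc(Nc2ncnc3cc(NC(=O)CCCCCCC(=O)NO)sc23)c1` differs from compound 3 in one place: cyano in place of ethynyl on an aromatic carbon. The measured step that bears most directly on this exchange is the one in which ethynyl replaced ethyl, a 2.7-fold lower number from compound 2 to compound 3 (0.44 log units; beyond the scatter), a modest gain; the other two steps change the whole aryl group at once. For the measured compounds named here, no measured step shows cyano anywhere, so the size of the coming step can only be judged from the spread among the three aryl variants, which stays modest throughout. In this assay the number for compound 4 is expected to sit near that of compound 3, with a step of a 1.4-fold higher number from compound 3 to compound 4 (0.15 log units; within the scatter) and a somewhat larger chance of a weaker than of a stronger result. The estimate for compound 4 is 30 nM, with a range from 12 nM to 75 nM.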

Compound 4, half-maximal inhibitory concentration: 20.1 nM
For compound 4 the middle estimate is 1.5-fold (0.17 log units) above the measured one; the range from low to high includes it.
By their numbers in this assay, from the lowest: compounds 4 and 3 (each within the scatter of the next); then compounds 2 and 1 (each within the scatter of the next).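

In this assay, cyano and ethynyl cannot be told apart at this position (a 1.1-fold lower number from compound 3 to compound 4 (0.03 log units; within the scatter)), even though cyano brings one hydrogen-bond acceptor and ethynyl none. The gain over ethyl is therefore not unique to ethynyl, as cyano also shows it (a 2.9-fold lower number from compound 2 to compound 4 (0.46 log units; beyond the scatter)), and the full aryl exchange gives a similar reading (a 4.4-fold lower number from compound 1 to compound 4 (0.64 log units; beyond the scatter)). Both groups that beat ethyl carry a triple bond outside the aromatic ring, but nothing available explains the match between them.

Open, from the compounds shown here alone, is whether a triple bond matters here at all: chloro, methoxy or an amine on the same aromatic carbon would test that. Also open, going by these compounds, is whether a longer alkyne such as propargyl keeps the number of compound 4 20.1 nM.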